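Longer ester chain on compound 2: cytotoxicity of compound 3

The compounds below may be only part of what the source reports. "The series", "measured", "known", "first", "only" and "open" are said of these compounds alone.

Measured compounds:
compound 1 `CCCCCCCCCOC(=O)CCC(=O)N1CCN(CCCOc2cc3c(Nc4ccc(F)c(Cl)c4)ncnc3cc2OC)CC1` — 7.8%
compound 2 `CCCCCCCCCCCCCOC(=O)CCC(=O)N1CCN(CCCOc2cc3c(Nc4ccc(F)c(Cl)c4)ncnc3cc2OC)CC1` — 6.8%

In a functional assay on A549 cells (Homo sapiens) for cytotoxicity, read by MTT assay, with a stated time of 24 h, tested at 80 uM (a higher number here means a weaker effect of the compound at the concentration tested, a lower number a stronger effect), compound 1 gives 7.8% while compound 2 gives 6.8%. Among the measured compounds shown here, compound 2 holds the lowest of the two numbers, but its only neighbour, compound 1, lies within the scatter of it. Compound 3 `CCCCCCCCCCCCCCCCCOC(=O)CCC(=O)N1CCN(CCCOc2cc3c(Nc4ccc(F)c(Cl)c4)ncnc3cc2OC)CC1` differs from compound 2 by butyl in place of hydrogen on a saturated chain carbon, ten or more bonds along the chain from an oxygen next to a carbonyl group. For the measured compounds named here, the one measured step that bears on this change is a number 1 percentage points lower from compound 1 to compound 2 (within the scatter), which stayed within the scatter. For compound 3 the expected step in this assay is therefore a number 0.3 percentage points lower from compound 2 to compound 3 (within the scatter), none beyond the scatter. Compound 3 is estimated at 6.5%, within 1% to 14%.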

Compound 3, a percentage reported as activity, at one concentration (the size of the read-out at that concentration, not a potency): 83.2%
Estimate against measurement, compound 3: 76.7 percentage points below; the whole stated range lies below it.
By their numbers in this assay, from the lowest: compounds 2 and 1 (each within the scatter of the next); then compound 3.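

In this assay the length of the ester chain is not neutral at this position: butyl in place of hydrogen gives a number 76.4 percentage points higher from compound 2 to compound 3 (beyond the scatter), and octyl in place of hydrogen gives a number 75.4 percentage points higher from compound 1 to compound 3 (beyond the scatter). The earlier pair showed no step beyond the scatter, so this large loss of effect at the tested concentration appears only with the longest chain shown. Nothing available explains this loss. From the compounds shown here alone, it remains open whether a chain of intermediate length would keep the effect, and whether a carboxylic acid or an amine carried on the long chain would restore it.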